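The source may report more compounds than this note shows. Statements on the series, on what has been measured and on what is new or still open speak of the compounds shown alone.

Measured compounds in a functional assay on B16 cells (Mus musculus) for cytotoxicity, read by MTT assay; a lower number here means a stronger inhibitor, a higher number a weaker inhibitor:
compound 1 `CC(=O)[C@@]1(C)C(=O)O[C@@H](OC(=O)c2ccccc2)[C@H]1C` gives 1000 nM
compound 2 `CC(=O)O[C@@H]1OC(=O)[C@@](C)(C(C)=O)[C@@H]1C` gives 14000 nM
compound 3 `CC(=O)[C@]1(C)C(=O)O[C@@H](OC(=O)C(C)(C)C)[C@H]1C` gives 10000 nM

Compound 3 stands second highest among these three numbers. Its nearest neighbour is compound 2, whose number is higher, and the step of a 1.4-fold lower number from compound 2 to compound 3 (0.15 log units; within the scatter) is within the scatter. Its furthest neighbour is compound 1, which gives a lower number, a gap beyond the scatter.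

Compound 4 `CC(=O)[C@]1(C)C(=O)O[C@@H](OC(=O)c2ccccc2)[C@H]1C` is the next compound, not yet measured. From compound 3 to compound 4 the change is phenyl in place of tert-butyl on a carbonyl carbon. Going by the values given here, only one measured step touches this carbonyl carbon, the step of a 1.4-fold lower number from compound 2 to compound 3 (0.15 log units; within the scatter), which exchanged one alkyl group for a larger one without leaving the scatter. Among the compounds with values here, no measured step exchanges an alkyl group for an aromatic one, so the size of the coming step is uncertain. Compound 1 is the other compound bearing a phenyl on that carbonyl carbon, and in this assay compound 1 gives 1000 nM, the lowest number of the three. Compound 4 is therefore expected to move toward a lower number than compound 3, with a step of about a 3.3-fold lower number from compound 3 to compound 4 (0.52 log units; beyond the scatter). The estimate for compound 4 in this assay is 3000 nM, within a range from 800 nM to 12000 nM.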

Compound 4, half-maximal inhibitory concentration: 5000 nM
For compound 4 the middle estimate is 1.7-fold (0.22 log units) below the measured one; the range from low to high includes it.
By their numbers in this assay, from the lowest: compound 1; then compounds 4, 3 and 2 (each within the scatter of the next, the first and the last beyond it).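

In this assay, phenyl in place of tert-butyl on this carbonyl carbon gives a 2.0-fold lower number from compound 3 to compound 4 (0.30 log units; within the scatter), so the exchange of an alkyl group for an aromatic ring stays inside the scatter, while phenyl in place of methyl gives a 2.8-fold lower number from compound 2 to compound 4 (0.45 log units; beyond the scatter), a modest step beyond it. Phenyl on this carbonyl carbon therefore does not by itself bring the number of compound 1, which the earlier compounds could not show, as compound 1 was the only one carrying phenyl there. Also beyond the scatter, and with no change of group at all, is a 5.0-fold higher number from compound 1 to compound 4 (0.70 log units; beyond the scatter), which ties the difference to one stereocentre at a saturated ring carbon, the only point that separates this pair: the fact that compounds 1 and 4 differ only in the configuration as drawn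

The compounds shown leave open whether that stereocentre carries the same weight when tert-butyl or methyl sits on the carbonyl carbon. Also open, as far as these compounds go, is how a longer chain on this carbonyl carbon, or an amine or a carboxylic acid on the phenyl ring, would read in this assay.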